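Changing the amide group of compound 2

The source may hold more compounds than are shown below. What is called first, only, known or untested is meant among the compounds shown, and "the series" means these compounds.

Compound 1 `CCOc1ccc(NC(=O)C2Cc3cc(OC)c(OC)cc3C2=O)cc1`: 48.2 ug/mL
Compound 2 `COc1cc2c(cc1OC)C(=O)C(C(=O)Nc1ccc(Cl)cc1)C2`: 56.8 ug/mL
Compound 3 `CCOc1cccc(NC(=O)C2Cc3cc(OC)c(OC)cc3C2=O)c1`: 44.9 ug/mL

These three compounds were measured in a physicochemical assay, with a stated time of 30 min; on this read-out higher numbers stand for weaker inhibition and lower numbers for stronger inhibition. Compound 2 gives 56.8 ug/mL, and this value lies within the scatter of the values for both compound 1 and compound 3, so the three stand level.

The next compound to be measured is compound 4 `COc1cc2c(cc1OC)C(=O)C(C(=O)Nc1ccccc1C)C2`. It keeps the core of compound 2 and changes one group: 2-methylphenyl in place of 4-chlorophenyl on an amide-type nitrogen. Here 2-methylphenyl takes the place of 4-chlorophenyl on an amide-type nitrogen.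

Going by the values given here, only one measured step involves compound 2 and a change to this part of the molecule: a 1.2-fold higher number from compound 1 to compound 2 (0.07 log units; within the scatter). That step swaps chloro for ethoxy, and it stays within the scatter. Compound 1 gives 48.2 ug/mL and compound 3 gives 44.9 ug/mL, and these two values are also within the scatter of each other.

Among the compounds with values here, no measured compound carries a 2-methylphenyl group, and three values are a thin basis, so the range must stay wide. In this assay, no step beyond the scatter is expected, and no direction can be claimed with confidence. The expected change is a 1.1-fold lower number from compound 2 to compound 4 (0.06 log units; within the scatter). For compound 4 the estimated value is 50 ug/mL, with an expected range from 30 ug/mL to 80 ug/mL.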

Compound 4, half-maximal inhibitory concentration: 43.7 ug/mL
Compound 4: the middle estimate sits 1.1-fold (0.06 log units) above what was measured; the range from low to high includes it.
By their numbers in this assay, from the lowest: compounds 4, 3, 1 and 2 (each within the scatter of the next).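

Going by these compounds alone, the new step, a 1.3-fold lower number from compound 2 to compound 4 (0.11 log units; within the scatter), was measured in this assay and shows that this part of the molecule tolerates more than the earlier compounds showed: all of them carried an oxygen-linked ethoxy group or a chloro group on the phenyl ring, whereas compound 4 carries a plain methyl group, and all four compounds still stand level. The swap replaces 4-chlorophenyl with 2-methylphenyl, and the group and its place on the ring change together. This single step cannot separate the two changes and shows only that their combined result stays within the scatter. Nothing available here offers an explanation for this result.

From the compounds shown here alone, all four compounds keep a substituted phenyl ring on the amide-type nitrogen, so it remains open whether a longer alkyl chain in place of that ring would leave the number equally unchanged. It also remains open whether an amine or a carboxylic acid on the ring would finally produce a step beyond the scatter, which none of the compounds shown here does.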